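The source may report more compounds than this note shows. Statements on the series, on what has been measured and on what is new or still open speak of the compounds shown alone.

In a functional assay on Bel-7402 cells (Homo sapiens) for inhibition, read by MTT assay, with a stated time of 24 h, tested at 100 ug/mL (on this read-out higher numbers stand for more inhibition of growth at the one concentration tested and lower numbers for less inhibition of growth), two compounds sharing one core have been measured so far. Compound 1 `O=C(CCCCC(S)CCS)Nc1ccccc1` gives 7.67%, and compound 2 `O=C(CCCCC(S)CCS)Nc1cccc(C(F)(F)F)c1` gives 25.3%, so compound 2 holds the higher of the two numbers. The gap between them is modest but lies beyond the scatter.

The next compound, compound 3 `Cc1cccc(NC(=O)CCCCC(S)CCS)c1`, keeps that core and alters a single group. The change is methyl in place of trifluoromethyl on an aromatic carbon, with methyl in place of trifluoromethyl on an aromatic carbon.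

Among the measured compounds shown here, only one measured step bears on this change: a number 17.6 percentage points higher from compound 1 to compound 2 (beyond the scatter), which came with trifluoromethyl in place of hydrogen on an aromatic carbon. For the measured compounds named here, no measured compound yet carries methyl, so that step offers only an indirect guide. The new change removes the same trifluoromethyl group, so a drop of somewhat less than that full size is expected in this assay, though the data cannot fix it closely. The expected change is a number 11.3 percentage points lower from compound 2 to compound 3 (beyond the scatter). For compound 3 the estimated value is 14%, with an expected range from 4% to 27%.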

Compound 3, percent growth inhibition at one concentration: 7.08%
For compound 3 the middle estimate is 6.9 percentage points above the measured one; measured number inside the range.
By their numbers in this assay, from the lowest: compounds 3 and 1 (each within the scatter of the next); then compound 2.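

In this assay, methyl in place of trifluoromethyl gives a number 18.2 percentage points lower from compound 2 to compound 3 (beyond the scatter) and so shows that the higher number of compound 2 does not carry over to every small group on this aromatic carbon, meta to a large group. Methyl in place of hydrogen gives a number 0.6 percentage points lower from compound 1 to compound 3 (within the scatter) and so leaves methyl on this carbon indistinguishable from hydrogen on this read-out, which the first pair alone could not show. Among the three compounds, trifluoromethyl is thus the only group at this place whose number stands apart from the others, and no available data explain why.

From the compounds shown here alone, whether the number of compound 2 depends on fluorine as such stays open, as does where a chlorine, a methoxy group or a nitrile on this same carbon would fall relative to compound 2 and compound 1. Also open, going by these compounds, is whether the gap between these compounds would hold at other concentrations, since each has one reading at a single concentration.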